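The compounds below may be only part of what the source reports. "The series", "measured", "known", "first", "only" and "open" are said of these compounds alone.

Working notes on the series. Four compounds share one core: compound 1 `N#CC1=C(N)Oc2c(c3nc4ccccc4nc3c3ccccc23)C12C(=O)N(Cc1cnnn1-c1ccc(S(N)(=O)=O)cc1)c1ccccc12`, compound 2 `N#CC1=C(N)Oc2c(c3nc4ccccc4nc3c3ccccc23)C12C(=O)N(Cc1cnnn1-c1ccc(F)c(Cl)c1)c1ccccc12`, compound 3 `Cc1cccc(-n2nncc2CN2C(=O)C3(C(C#N)=C(N)Oc4c(N)cc5nc6ccccc6nc5c43)c3ccccc32)c1` and the not yet measured compound 4 `N#CC1=C(N)Oc2c(N)cc3nc4ccccc4nc3c2C12C(=O)N(Cc1cnnn1-c1ccccc1Cl)c1ccccc12`. In a functional assay on HepG2 cells (Homo sapiens) for antiproliferative activity, read by MTT assay, with a stated time of 48 h (a lower number here means a stronger inhibitor, a higher number a weaker inhibitor), compound 1 gives 42200 nM. For compound 2 this assay reports only a limit, > 50000 nM. For compound 3 it likewise reports only a limit, > 50000 nM. Compound 3 thus stands where the weak end of the set is marked by the limit of > 50000 nM in this assay, at which 2 of the 3 values shown sit, with no number of its own to rank it against compound 1.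

The change to compound 4 is 2-chlorophenyl in place of 3-methylphenyl on an aromatic nitrogen. For the measured compounds named here, only one measured step bears on it, an exchange of the aryl group on an aromatic nitrogen: an at least 1.1-fold higher number from compound 1 to compound 2 (0.07 log units; that floor lies within the scatter). That step is itself capped by a limit and amounts to no change beyond the scatter; it gives no sign that swapping the aryl group at this position moves this assay. Compound 4 is therefore expected to remain at or near the limit, with no step beyond the scatter in either direction. The estimated step is a step that the limit leaves unreadable from compound 3 to compound 4. Compound 4 is expected to give about 60000 nM in this assay, within a range from 25000 nM to 150000 nM, most likely returned again as a limit rather than a number.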

Compound 4, half-maximal inhibitory concentration: 33500 nM
Compound 4: the middle estimate sits 1.8-fold (0.25 log units) above what was measured, and the stated range covers the measured number.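

In this assay, 2-chlorophenyl in place of 3-methylphenyl on an aromatic nitrogen gives an at least 1.4-fold lower number from compound 3 to compound 4 (0.17 log units; that floor lies within the scatter). Only that floor can be read and the full size of the step stays hidden, because compound 3 has no number of its own: the limit of > 50000 nM in this assay, at which 2 of the 4 values shown sit. For the compounds shown here, what the earlier compounds did not show is that an aryl exchange at this position can end on a number rather than a limit, and compound 4 is the first compound with the core of compound 3 to do so, though the floor of the step does not by itself set compound 4 apart from compound 3.

On these data alone, it remains open whether the step follows the chlorine or its place on the ring, since both change together here, and 3-chlorophenyl or 2-methylphenyl at this position would separate the two. Also open, as far as these compounds go, is how this assay would read with an amine or a carboxylic acid on this phenyl ring, or with a longer alkyl chain in place of the ring.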